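Cyclopentyl Amide on a Dimethoxy Tetralin Acetamide Core

The source may hold more compounds than are shown below. What is called first, only, known or untested is meant among the compounds shown, and "the series" means these compounds.

compound 1 `CCNC(=O)CC1CCc2cc(OC)c(OC)cc21`: 15.6%
compound 2 `CCCNC(=O)CC1CCc2cc(OC)c(OC)cc21`: 18.8%

In a functional assay on the whole organism (strain Wistar) for inhibition, with Rattus norvegicus as the target, read by paw edema, with stated times of 60 min and 1 h, at a dose of 100 mg/kg by the oral route (a lower number here means less inhibition, a higher number more inhibition at the dose given (going by the name of the read-out)), compound 2 gives 18.8% and stands alongside compound 1, the two numbers within the scatter of each other, since a number 3.2 percentage points higher from compound 1 to compound 2 (within the scatter). Compound 3 `COc1cc2c(cc1OC)C(CC(=O)NC1CCCC1)CC2` is reached from compound 2 by one change: cyclopentyl in place of propyl on an amide-type nitrogen. Going by the values given here, the only measured step on the amide nitrogen side is a number 3.2 percentage points higher from compound 1 to compound 2 (within the scatter), a small one. No step beyond the scatter is therefore expected in this assay from compound 2 to compound 3. Compound 3 is expected to give 22%, in the range 8% to 38%, an expected step of a number 3.2 percentage points higher from compound 2 to compound 3 (within the scatter).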

Compound 3, a percentage reported as inhibition, in the whole organism at one dose (the size of the read-out at that dose, not a potency): 40.6%
Compound 3: the middle estimate sits 18.6 percentage points below what was measured, and the stated range ends below it.
By their numbers in this assay, from the lowest: compounds 1 and 2 (each within the scatter of the next); then compound 3.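

In this assay the amide nitrogen turns out to be a place where one change can move the read-out beyond the scatter: cyclopentyl in place of propyl gives a number 21.8 percentage points higher from compound 2 to compound 3 (beyond the scatter), and cyclopentyl in place of ethyl gives a number 25 percentage points higher from compound 1 to compound 3 (beyond the scatter). The earlier step between the open chains showed nothing of this size. No measurement at hand accounts for the step. As far as these compounds go, it stays open whether the ring or the carbon count carries the step, which a pentyl chain on this nitrogen would help to separate. From the compounds shown here alone, how cyclobutyl or cyclohexyl would compare also remains open.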